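Smaller Amine on the Bridged Core: Compound 3 to Compound 4

The compounds below may be only part of what the source reports. "The series", "measured", "known", "first", "only" and "open" are said of these compounds alone.

Of the compounds shown here, three sharing a bridged core have been measured in an ADME assay on L6 cells (Rattus norvegicus) for cytotoxicity, with a stated time of 72 h; a higher number here means a weaker inhibitor, a lower number a stronger inhibitor. Compound 1 `O=C(/C=C/c1ccccc1)OC1CC2(N3CCCCC3)CC(c3ccccc3)C1C(c1ccccc1)C2` gives 10500 nM. Compound 2 `CCN(CC)CC(=O)OC1CC2(N3CCCC3)CC(c3ccccc3)C1C(c1ccccc1)C2` gives 49000 nM. Compound 3 `O=C(/C=C/c1ccccc1)OC1CC2(N3CCCC3)CC(c3ccccc3)C1C(c1ccccc1)C2` gives 3500 nM, the lowest of the three numbers, and both of its neighbours lie beyond the scatter: a 3.0-fold lower number from compound 1 to compound 3 (0.48 log units; beyond the scatter) and a 14-fold lower number from compound 2 to compound 3 (1.15 log units; beyond the scatter).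

Compound 4 `CN(C)C12CC(OC(=O)/C=C/c3ccccc3)C(C(c3ccccc3)C1)C(c1ccccc1)C2` is not yet measured. It differs from compound 3 in one place: dimethylamino in place of pyrrolidin-1-yl on a saturated ring carbon. Within the data shown here, the only measured step that touches the same saturated ring carbon is the one from compound 1 to compound 3, where pyrrolidin-1-yl replaced piperidin-1-yl and the number fell modestly. The step from compound 2 to compound 3 changed the carbonyl substituent and does not bear on this position. Nothing measured here shows an acyclic amine at this carbon, so the direction is open. Compound 4 is therefore expected to stay near compound 3, with a 1.1-fold higher number from compound 3 to compound 4 (0.06 log units; within the scatter) in this assay, and its estimated value is 4000 nM, within a range from 1500 nM to 11000 nM.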

Compound 4, half-maximal inhibitory concentration: 3820 nM
Estimate against measurement, compound 4: 1.0-fold (0.02 log units) above; the range from low to high includes it.
By their numbers in this assay, from the lowest: compounds 3 and 4 (each within the scatter of the next); then compound 1; then compound 2.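

In this assay, among these compounds, dimethylamino is the first amine without a ring on this saturated ring carbon, and it reads level with pyrrolidin-1-yl (a 1.1-fold higher number from compound 3 to compound 4 (0.04 log units; within the scatter)), so at this position, with this ester, removing the five-membered ring leaves the number within the scatter. Piperidin-1-yl now stands apart from both of the smaller amines, since the step to dimethylamino (a 2.7-fold lower number from compound 1 to compound 4 (0.44 log units; beyond the scatter)) is about the size of the step to pyrrolidin-1-yl, and no listed compound goes against this. Nothing available explains why these amines group as they do.

From the compounds shown here alone, it remains open whether an acyclic amine with longer chains, such as diethylamino, or a ring amine with a second hetero atom, such as morpholin-4-yl, would read with the smaller amines or with piperidin-1-yl. Going by these compounds, it is also open whether dimethylamino would stay level with pyrrolidin-1-yl on the (diethylamino)methyl ester of compound 2.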